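The compounds below may be only part of what the source reports. "The series", "measured", "known", "first", "only" and "open" are said of these compounds alone.

Measured so far in a functional assay on Jurkat cells (Homo sapiens); on this read-out lower numbers stand for stronger inhibition and higher numbers for weaker inhibition:
- compound 1 `CC(C)[C@H](NC(=O)COc1cccc2ccccc12)C(=O)N[C@@H](CC(=O)O)C(=O)COc1ccccc1F`: > 100000 nM, a limit of the assay
- compound 2 `CC(C)[C@H](NC(=O)COc1cccc2ccccc12)C(=O)N[C@@H](CC(=O)O)C(=O)COc1c(F)ccc(F)c1F`: 1200 nM

Among the compounds with values here, compound 2 carries the only actual number so far, so it has no measured neighbour to be ranked against beyond the limit of compound 1.

Next is compound 3 `CC(C)[C@H](NC(=O)COc1cccc2ccccc12)C(=O)N[C@@H](CC(=O)O)C(=O)COc1ccc(F)c(F)c1F`, which keeps the shared core and differs only in the fluorinated ring: 2,3,4-trifluorophenyl in place of 2,3,6-trifluorophenyl on an oxygen on a saturated carbon. The two have the same atoms, joined differently.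

Within the data shown here, one measured step bears on this: an at least 83-fold lower number from compound 1 to compound 2 (1.92 log units; beyond the scatter). It is large and beyond the scatter, and it also changed the group on the same oxygen, so this group can matter a great deal in this assay. That step replaced 2-fluorophenyl with 2,3,6-trifluorophenyl, whereas compound 3 keeps three fluorines, so a change of that size is not expected here. Weaker inhibition is the more likely direction, though no measured pair tests this exact change.

The expected size and direction are a 2.9-fold higher number from compound 2 to compound 3 (0.46 log units; beyond the scatter), an estimate with wide uncertainty.

For compound 3 the estimated value is 3500 nM, with an expected range of 500 nM to 30000 nM.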

Compound 3, half-maximal inhibitory concentration: 35800 nM
Beside the measured number, compound 3's estimate is 10-fold (1.01 log units) below it; measured number outside the range, above it.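

In this assay, three fluorines on the ring do not by themselves secure the lower number: with the same atoms joined differently, 2,3,4-trifluorophenyl in place of 2,3,6-trifluorophenyl on this oxygen gives a 30-fold higher number from compound 2 to compound 3 (1.47 log units; beyond the scatter), so the fluorine pattern alone can produce a large step. Against the 2-fluorophenyl group, 2,3,4-trifluorophenyl gives an at least 2.7-fold lower number from compound 1 to compound 3 (0.44 log units; beyond the scatter), which still leaves a measurable gain from the added fluorines, while compound 2 has the lowest number of the three, with its steps to both others beyond the scatter. The size of that gain remains a bound, set by compound 1, whose value is a limit of the assay: the limit of > 100000 nM in this assay, at which 1 of the 3 values shown sits.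

The three compounds do not separate the contribution of each fluorine position, and an unsubstituted phenyl or a pentafluorophenyl on the same oxygen would show whether the trend extends to either end of the fluorine count. From the compounds shown here alone, whether chlorine can stand in for fluorine on this ring, and whether the pattern holds with the carboxylic acid of the shared core replaced by an ester, also remains open.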